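The compounds below may be only part of what the source reports. "The series", "measured", "known", "first", "only" and "open" are said of these compounds alone.

Compound 1 `CC(C)C(NC(=O)c1ccccc1)C(=O)N1CCN(c2ccc(Cl)cc2)CC1`: 525 nM
Compound 2 `CC(C)[C@@H](NC(=O)CC1CC1)C(=O)N1CCC(c2ccc(Cl)cc2)CC1`: 46 nM
Compound 3 `CC[C@@H](C)[C@@H](NC(=O)CCc1ccccc1)C(=O)N1CCC(c2ccc(Cl)cc2)CC1`: 66 nM

All three were tested in an assay on THP-1 cells for displacement of a labelled ligand from C-C chemokine receptor type 1 (Homo sapiens); a higher number here means a weaker inhibitor, a lower number a stronger inhibitor. Compound 2 gives the lowest of the three numbers; compound 3 sits within the scatter of it, so the two cannot be told apart, whereas compound 1 lies well beyond the scatter above compound 2. Compound 4 `CC(C)CC(=O)N[C@@H](C(=O)N1CCC(c2ccc(Cl)cc2)CC1)C(C)C` has not yet been measured in this assay. It differs from compound 2 by isopropyl in place of cyclopropyl on a saturated chain carbon bound to a carbonyl carbon. Among the compounds with values here, with no comparable pair among the measured compounds, the expected step is none beyond the scatter, in either direction, and the estimate means a 1.2-fold higher number from compound 2 to compound 4 (0.08 log units; within the scatter). Compound 4 is therefore expected to give about 55 nM in this assay, with a likely range from 20 nM to 150 nM.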

Compound 4, half-maximal inhibitory concentration: 32 nM
Compound 4: middle estimate off by 1.7-fold (0.24 log units), on the high side; measured number inside the range.
By their numbers in this assay, from the lowest: compounds 4, 2 and 3 (each within the scatter of the next, the first and the last beyond it); then compound 1.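

In this assay, isopropyl in place of cyclopropyl on a saturated chain carbon bound to a carbonyl carbon gives a 1.4-fold lower number from compound 2 to compound 4 (0.16 log units; within the scatter), so the two compounds cannot be told apart. For this pair, the three-membered ring can be opened to a branched group of the same three carbons with no change beyond the scatter. The position therefore accepts either group in this assay.

Still open, on these data alone, is how an amine, a carboxylic acid or a longer chain at this place would read. Nothing shown here explains why cyclopropyl and isopropyl read alike.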